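The source may report more compounds than this note shows. Statements on the series, on what has been measured and on what is new or still open speak of the compounds shown alone.

In a functional assay on A549 cells (Homo sapiens) for inhibition, read by colorimetric assay and MTT assay, with a stated time of 72 h (a higher number here means a weaker inhibitor, a lower number a stronger inhibitor), the measured compounds give these values.

Compound 1 `COc1cc(C(=O)NNC(=S)Nc2csc(-c3ccccc3)c2)cc(OC)c1OC` gives (39000 nM)
Compound 2 `COc1cc(C(=O)NNC(=S)Nc2csc(-c3ccc(C)cc3)c2)cc(OC)c1OC` gives (39000 nM)
Compound 3 `COc1cc(OC)cc(C(=O)NNC(=S)Nc2csc(-c3ccccc3)c2)c1` gives (39000 nM)

Compound 1 stands level with compound 2 and compound 3 at the digits shown. Compound 4 `COc1ccc(C(=O)NNC(=S)Nc2csc(-c3ccccc3)c2)cc1OC` differs from compound 1 by one change (hydrogen in place of methoxy on an aromatic carbon), hydrogen in place of methoxy on an aromatic carbon. The same kind of exchange made elsewhere on that ring gave (no change at the digits printed from compound 1 to compound 3 (within the scatter)), and adding a methyl on the other aromatic ring gave (no change at the digits printed from compound 1 to compound 2 (within the scatter)). Neither step exceeds the scatter, so no step beyond the scatter is expected here (no change at the digits printed from compound 1 to compound 4 (within the scatter)). For compound 4 the estimate in this assay is (39000 nM), with an expected range from 18000 nM to (70000 nM).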

Compound 4, half-maximal inhibitory concentration: 20000 nM
For compound 4 the middle estimate is 2.0-fold (0.29 log units) above the measured one, within the range that was stated.
By their numbers in this assay, from the lowest: compounds 4, 1, 2 and 3 (each within the scatter of the next).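

In this assay hydrogen in place of methoxy, on the aromatic carbon ortho to a methoxy group and meta to a large group, gives a 2.0-fold lower number from compound 1 to compound 4 (0.29 log units; within the scatter) and so stays within the scatter. This position therefore accepts the loss of its methoxy without a step beyond the scatter, as the position changed in compound 3 does. No measurement here gives a cause for this small step.

From the compounds shown here alone, whether a hydroxyl, an amine or a longer chain at this position would move the value beyond the scatter stays open.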